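Replacing the bromo group of compound 2 with hydrogen

This account rests on a few compounds, and the source may have more. Where it says the series, first, only, none or still open, it means among the compounds named here.

Compound 1 `COc1ccc(-c2cnc(NC(=O)CCCCCCNC(=O)C(O)(O)C(F)(F)F)s2)cc1` gives 8510 nM
Compound 2 `O=C(CCCCCCNC(=O)C(O)(O)C(F)(F)F)Nc1ncc(-c2ccc(Br)cc2)s1` gives 11400 nM
Compound 3 `O=C(CCCCCCNC(=O)C(O)(O)C(F)(F)F)Nc1ccc(Br)cc1` gives 20900 nM

These numbers come from a functional assay on cells (Panel NCI-60 (60 carcinoma cell lines), Homo sapiens) for inhibition, read by colorimetric assay, with a stated time of 3 days (a lower number here means a stronger inhibitor of growth, a higher number a weaker inhibitor of growth), and they show compound 2 lying within the scatter of both compound 1 and compound 3, with no clear separation from either. Still unmeasured is compound 4 `O=C(CCCCCCNC(=O)C(O)(O)C(F)(F)F)Nc1ncc(-c2ccccc2)s1` which carries, compared with compound 2, hydrogen in place of bromo on an aromatic carbon. Within the data shown here, the one measured step at this carbon is a 1.3-fold higher number from compound 1 to compound 2 (0.13 log units; within the scatter) and it exchanged methoxy for bromo. Among the measured compounds shown here, no measured compound of this series has hydrogen there, so this small step is the only guide. On that guide, no change beyond the scatter is expected in this assay for this exchange either. The estimated size of the change is a 1.1-fold lower number from compound 2 to compound 4 (0.06 log units; within the scatter) and it should not be read as a real difference. For compound 4 the estimated value is 10000 nM with an expected range from 5000 nM to 21000 nM at the two ends.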

Compound 4, concentration for total growth inhibition: 17000 nM
For compound 4 the middle estimate is 1.7-fold (0.23 log units) below the measured one; measured number inside the range.
By their numbers in this assay, from the lowest: compounds 1, 2, 4 and 3 (each within the scatter of the next, the first and the last beyond it).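

With hydrogen now at this carbon, the para position of the phenyl ring carries three different substituents, and in this assay hydrogen in place of bromo gives a 1.5-fold higher number from compound 2 to compound 4 (0.17 log units; within the scatter), while hydrogen in place of methoxy gives a 2.0-fold higher number from compound 1 to compound 4 (0.30 log units; within the scatter). Both steps lie within the scatter, so neither bromo nor methoxy can be told apart from the unsubstituted phenyl here, and this small position shows no measurable preference among these three. No accompanying measurement helps to interpret this lack of separation.

On these data alone, it remains open whether an amine, a carboxylic acid or a nitrile at this carbon would move the number beyond the scatter. Also unresolved is whether any change here would matter more in a compound with a longer chain.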